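A few compounds are considered here, and "the series" means these few. Any claim that something is new, unique, unknown or untested is made for them only; others in the source may bear on it.

In a functional assay for agonist activity at G protein-coupled receptor 88 (Homo sapiens), read by HTRF and cAMP accumulation (on this read-out lower numbers stand for an effect already at smaller amounts and higher numbers for an effect only at larger amounts of compound), compound 1 `CC(C)C[C@H](N)CN(C(=O)[C@@H]1C[C@H]1c1ccccc1)c1ccc(-c2ccccc2F)cc1` gives 1600 nM and compound 2 `CCc1ccc(-c2ccc(N(C[C@@H](N)[C@@H](C)CC)C(=O)[C@@H]3C[C@H]3c3ccccc3)cc2)cc1` gives 44 nM; compound 2 thus holds the lower of the two numbers shown, and the gap to compound 1 lies beyond the scatter. Compound 3 `CC[C@H](C)[C@H](N)CN(C(=O)[C@@H]1C[C@H]1c1ccccc1)c1ccc(-c2ccc(CN(C)C)cc2)cc1` differs from compound 2 in one place: dimethylamino in place of methyl on a saturated chain carbon bound to an aromatic carbon. Going by the values given here, no measured pair shows this change, so its effect can only be guessed. The step of a 1.8-fold higher number from compound 2 to compound 3 (0.26 log units; within the scatter) is expected to be small, toward a somewhat higher number, close to the scatter. Compound 3 is therefore expected to give about 80 nM in this assay, within a range from 20 nM to 400 nM.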

Compound 3, half-maximal effective concentration: 460 nM
For compound 3 the middle estimate is 5.8-fold (0.76 log units) below the measured one; the whole stated range lies below it.
By their numbers in this assay, from the lowest: compound 2; then compound 3; then compound 1.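

In this assay, dimethylamino in place of methyl on a saturated chain carbon bound to an aromatic carbon gives a 10-fold higher number from compound 2 to compound 3 (1.02 log units; beyond the scatter), a large step. This position is therefore sensitive to the group placed on it, and the shared core alone does not fix the number. No measurement here accounts for the step. From the compounds shown here alone, whether it follows the nitrogen of the dimethylamino group or simply the larger group remains open. A longer carbon chain or a methoxy group at this place would help separate the two.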